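Pyrrole carboxamide in place of benzamide: outlook for compound 3

The source may report more compounds than this note shows. Statements on the series, on what has been measured and on what is new or still open speak of the compounds shown alone.

Measured so far:
- compound 1 `CC(=O)Nc1nc2ccc(NC(=O)c3cc(Br)c(Br)[nH]3)cc2s1`: > 50000 nM
- compound 2 `CCOC(=O)C(=O)Nc1nc2ccc(NC(=O)c3ccccc3)cc2s1`: > 50000 nM
- compound 3 `CCOC(=O)C(=O)Nc1nc2ccc(NC(=O)c3cc(Br)c[nH]3)cc2s1`: not yet measured

In a functional assay on MCF7 cells (Homo sapiens) for antiproliferative activity (on this read-out lower numbers stand for an effect already at smaller amounts and higher numbers for an effect only at larger amounts of compound), compound 2 gives > 50000 nM, which is a limit of the assay and not a number. Compound 1 likewise gives > 50000 nM in this assay, again a limit. Both values shown therefore sit at the limit of > 50000 nM in this assay, at which 2 of the 2 values shown sit, so compound 2 has no numerical position within the series; no ordering between compound 1 and compound 2 can be read from them.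

Compound 3 is derived from compound 2 by 4-bromo-1H-pyrrol-2-yl in place of phenyl on a carbonyl carbon. Within the data shown here, no step between measured compounds is available for this change. Since both recorded values are limits, the expected step from compound 2 to compound 3 is a number no higher from compound 2 to compound 3 (the limit leaves the size open), that is, none beyond the scatter in this assay. The expected value for compound 3 is 50000 nM, with a range from 15000 nM to 100000 nM, most probably again reported only as a limit.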

Compound 3, half-maximal effective concentration: 41300 nM
Compound 3: the middle estimate sits 1.2-fold (0.08 log units) above what was measured, within the range that was stated.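

In this assay, among these compounds, compound 3 gives 41300 nM, the only value so far that is a number and not a limit. Phenyl going to 4-bromo-1H-pyrrol-2-yl on a carbonyl carbon gives an at least 1.2-fold lower number from compound 2 to compound 3 (0.08 log units; that floor lies within the scatter), so the change is not shown to do anything beyond the scatter. Only a floor can be stated for this step, because the value of compound 2 is a limit of the assay: the limit of > 50000 nM in this assay, at which 2 of the 3 values shown sit.

Compound 1 differs from compound 3 in more than one place, and the compounds shown do not separate the pyrrole ring from its bromine. On these data alone, what an unsubstituted pyrrole, or a carboxylic acid in place of the ethyl ester, would give in this assay stays open.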